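Replacing the outer ring of compound 3

This account rests on a few compounds, and the source may have more. Where it says the series, first, only, none or still open, it means among the compounds named here.

Measured so far in an assay on cells for activation of probable G-protein coupled receptor 34 (Mus musculus), with a stated time of 1 h; on this read-out higher numbers stand for larger maximal responses and lower numbers for smaller maximal responses:
- compound 1 `CCCCCCCCCCCOc1ccccc1CCC(=O)OCCCOP(=O)(O)OC[C@H](N)C(=O)O` gives 0.04
- compound 2 `N[C@@H](COP(=O)(O)OCCCOC(=O)CCc1ccccc1OCCCCOc1ccccc1)C(=O)O` gives 0.033
- compound 3 `Cc1ccccc1Oc1cccc(COc2ccccc2CCC(=O)OCCCOP(=O)(O)OC[C@H](N)C(=O)O)c1` gives 0.28

Compound 3 stands highest of the three numbers; its nearest neighbour is compound 1, and the gap to both compound 1 and compound 2 is beyond the scatter, so compound 3 is the most active compound of this small set.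

Compound 4 `N[C@@H](COP(=O)(O)OCCCOC(=O)CCc1ccccc1OCc1cccc(Oc2cccc(Cl)c2)c1)C(=O)O` has not yet been measured in this assay. It differs from compound 3 in one place: 3-chlorophenyl in place of 2-methylphenyl on an oxygen on an aromatic ring

Among the measured compounds shown here, only one measured step is known, a number 0.0070 lower from compound 1 to compound 2 (within the scatter), and it concerns a different part of the molecule, the long chain at the other end, where swapping a heptyl for a phenoxy left the number essentially unchanged. For the measured compounds named here, no measured pair shows what happens when the 2-methylphenyl is exchanged for another ring on that same oxygen, so there is nothing to point to a step in either direction.

For compound 4 the expectation is therefore a step of no change at the digits printed from compound 3 to compound 4 (within the scatter), that is, none beyond the scatter, with a wide range to reflect the lack of a guiding precedent. Compound 4 is estimated to reach 0.28 in this assay, between 0.12 and 0.5.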

Compound 4, intrinsic activity: the largest response reached, as a fraction of the reference agonist's: 0.53
Compound 4: middle estimate off by 0.25, on the low side, and the stated range ends below it.
By their numbers in this assay, from the lowest: compounds 2 and 1 (each within the scatter of the next); then compound 3; then compound 4.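

Exchanging the outer ring on this oxygen is the only single change shown that moves the response in this assay beyond the scatter, giving a number 0.25 higher from compound 3 to compound 4 (beyond the scatter). Among the compounds shown here, the one earlier step, a number 0.0070 lower from compound 1 to compound 2 (within the scatter), lay within the scatter and concerned a saturated chain rather than this ring. The departing 2-methylphenyl and the entering 3-chlorophenyl have the same number of heavy atoms, the same six-membered aromatic carbon ring and no hydrogen-bond donors or acceptors, so the maximal response here changed even though those counts stayed the same. Nothing measured here explains the rise.

This one swap changes both the substituent, chlorine for methyl, and its location on the ring, so the compounds shown cannot tell which of the two matters, or whether either would matter alone. As far as these compounds go, it also remains open how an unsubstituted phenyl, a bromine or a nitrile on this ring would compare, and whether the gain would carry over to compounds with the ester or the phosphate portion changed.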